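A few compounds are considered here, and "the series" means these few. Any claim that something is new, unique, unknown or untested is made for them only; others in the source may bear on it.

Measured in an assay on HEK293 cells for inhibition of Voltage-dependent T-type calcium channel subunit alpha-1G (Homo sapiens), read by fluorescence, tested at 10 uM; on this read-out lower numbers stand for less inhibition and higher numbers for more inhibition at the one concentration tested (going by the name of the read-out):
compound 1, `CCCc1nc(-c2ccccc2)c(CNCCN2CCN(c3cccc(C)c3)CC2)o1`: 43.1%
compound 2, `CCCc1nc(-c2ccccc2)c(CNCCCN2CCN(c3ccc(F)cc3)CC2)o1`: 62.5%
compound 3, `CCCc1nc(-c2ccccc2)c(CNCCCN2CCN(c3cccc(F)c3)CC2)o1`: 68.9%

Compound 1 stands lowest of the three numbers; compound 2 lies nearest to it and compound 3 furthest, both gaps beyond the scatter. Compound 4, `CCCc1nc(-c2ccccc2)c(CNCCN2CCN(c3ccccn3)CC2)o1`, is not yet measured in this assay. It differs from compound 1 in one place: pyridin-2-yl in place of 3-methylphenyl on an amine nitrogen in a ring. Among the compounds with values here, the only measured step between single-change neighbours, a number 6.4 percentage points higher from compound 2 to compound 3 (within the scatter), also exchanges the aromatic group on the amine nitrogen in the ring, but it stays within the scatter and does not involve a ring hetero atom, so it gives no direct guide to the present change. Compounds 2 and 3 differ from compound 1 in more than one place, so their higher numbers cannot be laid to the aromatic group alone. Within the data shown here, with no precedent for a six-membered aromatic ring with one hetero atom at this place, the expectation is a step from compound 1 of a number 3.1 percentage points lower from compound 1 to compound 4 (within the scatter), not beyond the scatter in either direction, and the estimate for compound 4 is 40%, between 20% and 62%.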

Compound 4, a percentage reported as inhibition, at one concentration (the size of the read-out at that concentration, not a potency): 48.1%
Estimate against measurement, compound 4: 8.1 percentage points below, and the stated range covers the measured number.
By their numbers in this assay, from the lowest: compounds 1 and 4 (each within the scatter of the next); then compounds 2 and 3 (each within the scatter of the next).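

In this assay, the exchange on the amine nitrogen in the ring gives a number 5 percentage points higher from compound 1 to compound 4 (within the scatter), so this read-out does not separate pyridin-2-yl from 3-methylphenyl at this place, even though the change brings in a ring hetero atom and a hydrogen-bond acceptor and removes a carbon-only aromatic ring. The fluorophenyl pair, at a number 6.4 percentage points higher from compound 2 to compound 3 (within the scatter), showed only that moving a fluorine on a carbon-only ring left the number within the scatter; the present step extends that picture to a six-membered aromatic ring with one hetero atom, for these two pairs only, and each pair carries its own chain on the shared core. Nothing available accounts for the outcome at this place.

Still open, as far as these compounds go, is whether a pyrimidine ring, a plain phenyl or a saturated cyclohexyl group at this nitrogen would also stay within the scatter of compound 1. No pair shown differs in the chain alone, so the part played by that chain in the higher numbers of compound 2 and compound 3 cannot be read.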